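This account rests on a few compounds, and the source may have more. Where it says the series, first, only, none or still open, it means among the compounds named here.

Working notes on the series. Going by the values given here, in a functional assay on MIA PaCa-2 cells (Homo sapiens) for antiproliferative activity, read by sulforhodamine B assay, with a stated time of 48 h (on this read-out lower numbers stand for stronger inhibition of growth and higher numbers for weaker inhibition of growth), compound 3 `O=C(NCc1cn(Cc2ccc(Cl)cc2)nn1)c1cn(-c2ccccc2)nc1-c1ccc(F)cc1` gives 280 nM, the lowest number among the three measured so far; compound 1 `O=C(NCc1cn(Cc2ccc(Cl)cc2)nn1)c1cn(-c2ccccc2)nc1-c1ccccc1` gives 8700 nM and compound 2 `COc1ccc(Cn2cc(CNC(=O)c3cn(-c4ccccc4)nc3-c3ccccc3)nn2)cc1` gives 10200 nM. The gap to the nearest of these is the step of a 31-fold lower number from compound 1 to compound 3 (1.49 log units; beyond the scatter), which sets compound 3 clearly apart. Compound 4 `COc1ccc(Cn2cc(CNC(=O)c3cn(-c4ccccc4)nc3-c3ccc(F)cc3)nn2)cc1` differs from compound 3 by the change (methoxy in place of chloro on an aromatic carbon). The same change has been measured once in this assay, as the step of a 1.2-fold higher number from compound 1 to compound 2 (0.07 log units; within the scatter), so for this assay no step beyond the scatter is expected from it here. Compound 4 is therefore estimated at 330 nM, with a range from 150 nM to 750 nM. The expected step of a 1.2-fold higher number from compound 3 to compound 4 (0.07 log units; within the scatter) stays within the scatter.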

Compound 4, concentration for 50% growth inhibition: 3700 nM
Compound 4: middle estimate off by 11-fold (1.05 log units), on the low side, outside the stated range (above it).
By their numbers in this assay, from the lowest: compound 3; then compound 4; then compounds 1 and 2 (each within the scatter of the next).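

In this assay, methoxy in place of chloro is no longer silent once the fluoro is present, giving a 13-fold higher number from compound 3 to compound 4 (1.12 log units; beyond the scatter), so the outcome of this change at this position depends on the core: the same change on two cores in this assay, a 1.2-fold higher number (0.07 log units; within the scatter) from compound 1 to compound 2 and a 13-fold higher number (1.12 log units; beyond the scatter) from compound 3 to compound 4, 11-fold (1.05 log units) apart, beyond the scatter of two such steps. Read the other way, the gain from fluoro in place of hydrogen is smaller with 4-methoxybenzyl present, at a 2.8-fold lower number from compound 2 to compound 4 (0.44 log units; beyond the scatter), so the two changes do not act independently across these four compounds: the same change on two cores in this assay, a 31-fold lower number (1.49 log units; beyond the scatter) from compound 1 to compound 3 and a 2.8-fold lower number (0.44 log units; beyond the scatter) from compound 2 to compound 4, 11-fold (1.05 log units) apart, beyond the scatter of two such steps. With only chloro and methoxy shown at this position, it remains open whether bromo or trifluoromethyl on the core of compound 3 would give a number closer to that of compound 3 or compound 4.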